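Series notes: amide side chain variation on the shared core

The compounds below may be only part of what the source reports. "The series", "measured", "known", "first", "only" and "open" are said of these compounds alone.

Two compounds of the series have numbers in a functional assay on MCF7 cells (Homo sapiens) for cytotoxicity, read by MTT assay, with a stated time of 24 h, tested at 6.4 ug/mL; on this read-out higher numbers stand for a stronger effect at the one concentration tested and lower numbers for a weaker effect. Compound 1 `Cn1c(-c2ccc(NC(=O)CSC3=NCCS3)cc2)nc(-c2ccccc2)c1-c1ccccc1` gives 18.6% in this assay. Compound 2 `Cn1ccnc1SCC(=O)Nc1ccc(-c2nc(-c3ccccc3)c(-c3ccccc3)n2C)cc1` gives 27.2% in this assay. Going by the values given here, the only step between them, a number 8.6 percentage points higher from compound 1 to compound 2 (within the scatter), is within the scatter, so compound 2 stands next to compound 1 rather than apart from it; the two numbers cannot be ordered on this evidence.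

Compound 3 `CN(C)/C=C/N1CCN(CC(=O)Nc2ccc(-c3nc(-c4ccccc4)c(-c4ccccc4)n3C)cc2)CC1` is the next compound to be measured in this assay. It differs from compound 2 in one place: 4-(2-(dimethylamino)ethenyl)piperazin-1-yl in place of (1-methyl-1H-imidazol-2-yl)sulfanyl on a saturated chain carbon bound to a carbonyl carbon. The measured step from compound 1 to compound 2 is the only one available and it also replaces the group attached at the end of the amide side chain, but there the sulfur stayed and one five-membered aromatic ring took the place of a five-membered non-aromatic ring; here the sulfur leaves with the ring and a six-membered non-aromatic ring enters on the saturated chain carbon bound to the carbonyl carbon. That earlier step was within the scatter, and nothing in the series shows this side chain moving the read-out beyond it. For compound 3 the step of a number 2.2 percentage points lower from compound 2 to compound 3 (within the scatter) is therefore expected to stay within the scatter. Compound 3 is estimated at 25%, with a range from 8% to 45%.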

Compound 3, a percentage reported as activity, at one concentration (the size of the read-out at that concentration, not a potency): 11.1%
Compound 3: middle estimate off by 13.9 percentage points, on the high side; measured number inside the range.
By their numbers in this assay, from the lowest: compounds 3, 1 and 2 (each within the scatter of the next, the first and the last beyond it).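

In this assay, going by these compounds alone, the group on a saturated chain carbon bound to a carbonyl carbon now shows a step that can be told apart from repeat variation: 4-(2-(dimethylamino)ethenyl)piperazin-1-yl in place of (1-methyl-1H-imidazol-2-yl)sulfanyl gives a number 16.1 percentage points lower from compound 2 to compound 3 (beyond the scatter), which no earlier pair showed. The same entering group, set against the sulfur-linked five-membered non-aromatic ring, gives a number 7.5 percentage points lower from compound 1 to compound 3 (within the scatter), so the change at this position separates only from the imidazole side chain and the effect of this group depends on which group it is compared with. Within the data shown here, no measurement on these compounds bears on the origin of either step.

Still open, as far as these compounds go, is whether the read-out follows the six-membered ring, the 2-(dimethylamino)ethenyl end or the departure of the sulfur, which all change in one step; a 4-methylpiperazin-1-yl or a (1-methyl-1H-imidazol-2-yl)amino group at the same place would separate these. With a single tested concentration, the compounds shown also leave open whether the gap persists at other concentrations.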